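The source may hold more compounds than are shown below. What is called first, only, known or untested is meant among the compounds shown, and "the series" means these compounds.

Compound 1, `CCOc1cc(NC(=O)CCCCCCC(=O)Nc2ccccc2N)cc2c1OCC([N+](=O)[O-])=C2`, gives 52% in an assay on isolated protein for inhibition of protein deacetylase HDAC6 (Homo sapiens), read by fluorescence, with stated times of 10 min and 30 min, tested at 10 uM; a lower number here means less inhibition, a higher number more inhibition at the concentration tested (going by the name of the read-out). Compound 2, `CCOc1cc(NC(=O)CCCCCC(=O)Nc2cc(-c3ccc(C)s3)ccc2N)cc2c1OCC([N+](=O)[O-])=C2`, gives 36% in this assay, the lower of the two numbers, with compound 1 standing beyond the usual scatter above it. Compound 3, `CCOc1cc(NC(=O)CCCCCC(=O)Nc2ccccc2N)cc2c1OCC([N+](=O)[O-])=C2`, is not yet measured; it differs from compound 2 by hydrogen in place of 5-methylthiophen-2-yl on an aromatic carbon and from compound 1 only in chain length. For compound 3 a rise in this assay is expected because compound 1 with the same unsubstituted ring reaches 52%. The expected step is a number 12 percentage points higher from compound 2 to compound 3 (beyond the scatter). Compound 3 is estimated at 48%, within 30% to 65%.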

Compound 3, a percentage reported as inhibition, at one concentration (the size of the read-out at that concentration, not a potency): 57%
For compound 3 the middle estimate is 9 percentage points below the measured one, within the range that was stated.
By their numbers in this assay, from the lowest: compound 2; then compounds 1 and 3 (each within the scatter of the next).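

Hydrogen in place of 5-methylthiophen-2-yl, on the aromatic carbon para to an amino group, gives a number 21 percentage points higher from compound 2 to compound 3 (beyond the scatter) in this assay, the first reading of this position in which nothing else differs. The change in chain length shows a number 5 percentage points higher from compound 1 to compound 3 (within the scatter), so these two chain lengths are not told apart in this assay. Nothing given here accounts for the drop that comes with the 5-methylthiophen-2-yl group. Still open, from the compounds shown here alone, is how a methyl or phenyl group at this position would read, and whether a longer chain would read the same.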